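The source may report more compounds than this note shows. Statements on the series, on what has been measured and on what is new or still open speak of the compounds shown alone.

Compound 1, `CCc1nc(NC(CC)CC)c(OC)nc1-c1ccc(OC(F)F)cc1Cl`, gives 1.4 nM in an assay on IMR-32 cells for displacement of a labelled ligand from corticotropin-releasing factor receptor 1 (Homo sapiens), read by scintillation counting, with a stated time of 2 h; on this read-out lower numbers stand for stronger inhibition and higher numbers for weaker inhibition.
Compound 2, `CCc1nc(-c2ccc(OC)cc2OC(F)(F)F)c(CC)nc1NC(CC)CC`, gives 4.1 nM.
Compound 3, `CCc1nc(-c2ccc(Cl)cc2Cl)c(CC)nc1NC(COC)COC`, gives 224 nM.

Among these three numbers compound 2 stands second highest. Its nearest neighbour is compound 1, whose value of 1.4 nM lies lower by a margin beyond the usual scatter; furthest from it is compound 3, whose value of 224 nM lies far higher, well beyond the scatter.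

Compound 4, `CCc1nc(-c2ccc(OC)cc2O)c(CC)nc1NC(CC)CC`, has not yet been measured in this assay. It differs from compound 2 in one place: hydrogen in place of trifluoromethyl on an oxygen on an aromatic ring. The same difference, cut one bond further out, reads trifluoromethoxy to hydroxy. Among the compounds with values here, no pair among the measured compounds shows this change on its own, so no measured step can be quoted for it; compounds 2 and 3 differ at several places at once, and their two values show only that compound 3 lies far higher than compound 2. What follows is therefore an expectation rather than a reading of a measured step. Compound 4 is expected to give a higher number than compound 2, by a step that goes beyond the scatter, a 12-fold higher number from compound 2 to compound 4 (1.09 log units; beyond the scatter). The estimate for compound 4 in this assay is 50 nM, with a range from 10 nM to 300 nM.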

Compound 4, inhibition constant: 1180 nM
Beside the measured number, compound 4's estimate is 24-fold (1.37 log units) below it; the whole stated range lies below it.
By their numbers in this assay, from the lowest: compound 1; then compound 2; then compound 3; then compound 4.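

In this assay, within the data shown here, replacing trifluoromethyl with hydrogen on the oxygen on the aromatic ring gives a 290-fold higher number from compound 2 to compound 4 (2.46 log units; beyond the scatter), the only step between compounds differing in one place, and it is large. With the rest of compound 2 unchanged, it shows that the number depends strongly on what this oxygen carries, which compounds 1 and 3, differing from compound 2 at several places at once, could not show. The data shown include no measurement that accounts for the size of this step.

Among the compounds shown, this oxygen carries only trifluoromethyl or hydrogen, so the step does not tell whether a methyl or an ethyl on the same oxygen would give a number near that of compound 2, near that of compound 4, or somewhere else. A single pair also leaves open whether the same change would have a step of similar size in a compound with the other amine substituent of compound 3 or with the methoxy group on the core of compound 1.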